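A few compounds are considered here, and "the series" means these few. Any claim that something is new, unique, unknown or untested is made for them only; others in the source may bear on it.

Compound 3 `CCCCCCCC/C=C\CCCCCCCCNC(=O)Nc1cc(C)ccc1C` is a urea that in an assay on microsomes from intestinal mucosa for inhibition of acyl-CoA:cholesterol acyltransferase (Oryctolagus cuniculus) (a lower number here means a stronger inhibitor, a higher number a weaker inhibitor), gives 4500 nM. Of the two compounds with a single number, compound 3 holds the lower one; its nearest neighbour is compound 2 `CCCCCCCC/C=C\CCCCCCCCNC(=O)c1c(C)cccc1C`, which in this assay gives 9800 nM. Compound 1 `CCCCCCCCCCCCCCCCCCNC(=O)Nc1c(C)cccc1C` was measured twice and in this assay gives 610 nM; 610 nM (2 entries). Within the data shown here, the only measured step, a 2.2-fold lower number from compound 2 to compound 3 (0.34 log units; beyond the scatter), is modest and exchanges the aryl pattern and the link at once, so it is a weak guide for an aryl exchange alone.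

Compound 4 `CCCCCCCC/C=C\CCCCCCCCNC(=O)Nc1c(CC)cccc1C(C)C` differs from compound 3 in one place: 2-ethyl-6-isopropylphenyl in place of 2,5-dimethylphenyl on an amide-type nitrogen. Among the measured compounds shown here, no measured step changes only the aryl group on a urea nitrogen. For the measured compounds named here, compound 1 carries 2,6-dimethylphenyl and compound 3 carries 2,5-dimethylphenyl, but the two also differ in the chain, so their numbers show only that the compound with the 2,6-pattern sits at the lower number, not a single step. Compound 4 carries two groups at the same ring positions as compound 1, so a step toward a lower number is expected, but its size is uncertain. Compound 4 is expected at 400 nM, within a range from 80 nM to 2000 nM. That estimate means an expected step of an 11-fold lower number from compound 3 to compound 4 (1.05 log units; beyond the scatter).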

Compound 4, half-maximal inhibitory concentration: 37 nM
Beside the measured number, compound 4's estimate is 11-fold (1.03 log units) above it; the whole stated range lies above it.
By their numbers in this assay, from the lowest: compound 4; then compound 3; then compound 2.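

In this assay, among these compounds, the step of a 120-fold lower number from compound 3 to compound 4 (2.09 log units; beyond the scatter) is the first measured change of the aryl group alone on the urea nitrogen, with the chain and the urea link held constant, and it is large. It shows that this position strongly affects the measured inhibition: an aryl group of 11 carbon atoms in place of one of 8, with no hydrogen-bond donors or acceptors in either, moves the number far beyond the usual scatter. Nothing measured here explains why this exchange has such an effect.

The exchange replaces both ring substituents and alters their pattern in a single move, leaving open whether the ethyl group, the isopropyl group or the pattern itself accounts for the step. Also open, on these data alone, is how a 2,6-diisopropylphenyl group, or an aryl group carrying an amine or a carboxylic acid, would behave on this same nitrogen.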